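The source may hold more compounds than are shown below. What is called first, only, known or untested is meant among the compounds shown, and "the series" means these compounds.

Measured compounds:
compound 1 `CCCCCCCCCSC[C@H](NC(C)=O)C(=O)CCl` — 7300 nM
compound 2 `CCCCCCCCCCCSC[C@H](NC(C)=O)C(=O)CCl` — 1700 nM
compound 3 `CCCCCCCCCCCCCCCCSC[C@H](NC(C)=O)C(=O)CCl` — 16000 nM

All three were tested in a functional assay on NALM-6 cells (Homo sapiens); on this read-out lower numbers stand for stronger inhibition and higher numbers for weaker inhibition. They share one core and differ only in how far the saturated chain on the sulfur runs. From compound 1 to compound 2 the change is ethyl in place of hydrogen on a saturated chain carbon, nine bonds along the chain from a sulfur and it gave a 4.3-fold lower number from compound 1 to compound 2 (0.63 log units; beyond the scatter). From compound 1 to compound 3 the change is heptyl in place of hydrogen on a saturated chain carbon, nine bonds along the chain from a sulfur, which gave a 2.2-fold higher number from compound 1 to compound 3 (0.34 log units; beyond the scatter), while a 9.4-fold higher number from compound 2 to compound 3 (0.97 log units; beyond the scatter).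

Compound 4 `CCCCCCCCCCCCCCCCCCSC[C@H](NC(C)=O)C(=O)CCl` has not yet been measured. It differs from compound 3 by ethyl in place of hydrogen on a saturated chain carbon, ten or more bonds along the chain from a sulfur. This is the same kind of change as from compound 1 to compound 2, though the place on the chain, as described for each change, is not identical. Because a 9.4-fold higher number from compound 2 to compound 3 (0.97 log units; beyond the scatter) shows that lengthening the already long chain weakened inhibition, compound 4 is expected to give a 1.6-fold higher number from compound 3 to compound 4 (0.19 log units; within the scatter) in this assay. The estimate for compound 4 is 25000 nM, expected to lie between 8000 nM and 80000 nM.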

Compound 4, half-maximal inhibitory concentration: > 100000 nM
Compound 4: only a limit was reported; the forecaster's own chance of this, stated with the estimate: 20%; middle value at least 4.0-fold (0.60 log units) away from the limit.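

In this assay compound 4 gives > 100000 nM, which is a limit of the assay and not a number. Ethyl in place of hydrogen gave an at least 6.2-fold higher number from compound 3 to compound 4 (0.79 log units; beyond the scatter), so on these long chains the change does not carry over from the core of compound 1 to the core of compound 3: the same change on two cores in this assay, a 4.3-fold lower number (0.63 log units; beyond the scatter) from compound 1 to compound 2 and an at least 6.2-fold higher number (0.79 log units; beyond the scatter) from compound 3 to compound 4, at least 26-fold (1.42 log units) apart, beyond the scatter of two such steps Heptyl in place of hydrogen gave an at least 58-fold higher number from compound 2 to compound 4 (1.76 log units; beyond the scatter) and nonyl gave an at least 13-fold higher number from compound 1 to compound 4 (1.13 log units; beyond the scatter), and the heptyl change does not carry over in size either, though the true size of these steps stays unknown: the same change on two cores in this assay, a 2.2-fold higher number (0.34 log units; beyond the scatter) from compound 1 to compound 3 and an at least 58-fold higher number (1.76 log units; beyond the scatter) from compound 2 to compound 4, at least 26-fold (1.42 log units) apart, beyond the scatter of two such steps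

The compounds shown leave open where, among chains longer than that of compound 2 and shorter than that of compound 3, the numbers begin to rise. They also leave open how a chain ending in an amine or a carboxylic acid would behave.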